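Purine series: hydroxyalkyl to hydroxyethoxy on the ring nitrogen

The source may hold more compounds than are shown below. What is called first, only, known or untested is meant among the compounds shown, and "the series" means these compounds.

Measured in a functional assay on MOLT-4 cells (Homo sapiens) for inhibition; a lower number here means a stronger inhibitor, a higher number a weaker inhibitor:
- compound 1 `CC(O)n1cnc2c(N)nc(I)nc21`: > 500000 nM, a limit of the assay.
- compound 2 `Nc1nc(I)nc2c1ncn2OCCO`: > 500000 nM, a limit of the assay.
- compound 3 `CC(O)n1cnc2c(S)nc(F)nc21`: > 500000 nM, a limit of the assay.

The change from compound 1 to compound 2 is 2-hydroxyethoxy in place of 1-hydroxyethyl on an aromatic nitrogen. In this assay it gives a step that the two limits leave unreadable from compound 1 to compound 2, since (the limit of > 500000 nM in this assay, at which 3 of the 3 values shown sit). The difference between the core of compound 1 and that of compound 3 is not broken down here. Compound 4 `OCCOn1cnc2c(S)nc(F)nc21` is still to be measured; it differs from compound 3 by 2-hydroxyethoxy in place of 1-hydroxyethyl on an aromatic nitrogen, the same change as before, at the same place. Compound 4 is therefore expected to stay at the limit as well, the expected step being a step that the limit leaves unreadable from compound 3 to compound 4, resting on the run from compound 1 to compound 2 and on compound 3 giving > 500000 nM. The estimate for compound 4 in this assay is 1000000 nM.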

Compound 4, half-maximal inhibitory concentration: 164000 nM
Beside the measured number, compound 4's estimate is 6.1-fold (0.79 log units) above it; measured number outside the range, below it.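

In this assay, 2-hydroxyethoxy in place of 1-hydroxyethyl on an aromatic nitrogen gives an at least 3.0-fold lower number from compound 3 to compound 4 (0.48 log units; beyond the scatter), so the change has a readable effect on the core of compound 3. Compound 3 gives > 500000 nM, a limit of the assay, so the step fixes only a minimum size. The same change on the core of compound 1 cannot be read, so it is not shown whether the change carries from one core to the other or holds only on the core of compound 3: the limit of > 500000 nM in this assay, at which 3 of the 4 values shown sit.

Open, from the compounds shown here alone, is whether a longer chain, or an amine or a carboxylic acid in place of the hydroxyl of the 2-hydroxyethoxy group, would keep this step. Also open, going by these compounds, is which part of the difference between the two cores decides whether the step appears.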